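The compounds below may be only part of what the source reports. "The series", "measured", "known", "first", "only" and "open" are said of these compounds alone.

Measured compounds: compound 1 `Cc1cccc(Oc2ccnc(N3CCN(C(=O)c4c(C)noc4C)CC3)n2)c1` with 0%; compound 2 `Clc1ccc2sc(CN3CCN(c4ncnc5c4CN(Cc4ccccc4)CC5)CC3)cc2c1` with 0%.

In an assay on isolated protein for inhibition of calcium/calmodulin-dependent protein kinase type IV (Homo sapiens), read by HTRF, tested at 10 uM (a higher number here means more inhibition at the concentration tested (going by the name of the read-out), a lower number less inhibition), compound 1 gives 0%. In this assay compound 2 gives 0%, level with compound 1 at the digits printed, within the scatter. Compound 3 `O=C(CN1CCN(c2ncnc3c2CN(Cc2ccccc2)CC3)CC1)Nc1cc(F)ccc1F` is not yet measured. It differs from compound 2 in one place: (2,5-difluorophenyl)carbamoyl in place of 5-chloro-1-benzothiophen-2-yl on a saturated chain carbon bound to an amine nitrogen in a ring. With both measured compounds showing no inhibition, no step beyond the scatter is expected; the step of a number 2 percentage points higher from compound 2 to compound 3 (within the scatter) is estimated as none beyond the scatter. For compound 3 the expected value is 2%, with a range from -8% to 15%.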

Compound 3, a percentage reported as inhibition, at one concentration (the size of the read-out at that concentration, not a potency): 0%
Beside the measured number, compound 3's estimate is 2 percentage points above it, and the stated range covers the measured number.
By their numbers in this assay, from the lowest: compounds 1, 2 and 3 (each within the scatter of the next).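

The change of 5-chloro-1-benzothiophen-2-yl to (2,5-difluorophenyl)carbamoyl on a saturated chain carbon bound to an amine nitrogen in a ring gives, in this assay, no change at the digits printed from compound 2 to compound 3 (within the scatter). This position thus carries either a two-ring aromatic group without a hydrogen-bond donor or a one-ring amide with one, and neither compound shows inhibition, so the step separates the two groups in no way. Nothing available explains this result.

As far as these compounds go, whether a carboxylic acid or a primary amine on this chain would give any inhibition stays open. So does whether the shared core of compound 2 and compound 3 can give any at all.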